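This account rests on a few compounds, and the source may have more. Where it says the series, first, only, none or still open, it means among the compounds named here.

Working notes on the series.

The shared core carries a benzyl-type ether whose aryl part varies. Compound 1 `O=c1c(OCc2ccccc2[N+](=O)[O-])c(-c2ccccc2)oc2cc(O)cc(O)c12` gives 51000 nM in an ADME assay on Huh-5-2 cells (Homo sapiens) for cytotoxicity, read by WST assay, with a stated time of 3 days; on this read-out higher numbers stand for lower toxicity in this test and lower numbers for higher toxicity in this test. Compound 2 `O=c1c(OCc2cccc([N+](=O)[O-])c2)c(-c2ccccc2)oc2cc(O)cc(O)c12` gives 31000 nM in this assay, and compound 3 `COc1cccc(COc2c(-c3ccccc3)oc3cc(O)cc(O)c3c2=O)c1` gives 28000 nM in this assay. All three values lie within the scatter of one another: a 1.8-fold lower number from compound 1 to compound 3 (0.26 log units; within the scatter), and a 1.1-fold lower number from compound 2 to compound 3 (0.04 log units; within the scatter), so compound 3 sits among the other two without a separable difference.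

The next compound, compound 4 `O=c1c(OCc2ccc([N+](=O)[O-])cc2)c(-c2ccccc2)oc2cc(O)cc(O)c12`, differs from compound 3 in one place: 4-nitrophenyl in place of 3-methoxyphenyl on a saturated chain carbon bound to an oxygen on an aromatic ring. Among the measured compounds shown here, two measured steps bear on it. Moving the nitro group around the ring gave a 1.6-fold lower number from compound 1 to compound 2 (0.22 log units; within the scatter), and exchanging nitro for methoxy on the aromatic carbon gave a 1.1-fold lower number from compound 2 to compound 3 (0.04 log units; within the scatter). Neither moving the nitro group nor swapping it for methoxy has shifted the read-out beyond the scatter, and the change to compound 4 is again a repositioning of the same kind of substituent on the same aryl ring. No step beyond the scatter is therefore expected, a 1.1-fold higher number from compound 3 to compound 4 (0.06 log units; within the scatter). Compound 4 is expected to give 32000 nM in this assay, with a range from 15000 nM to 65000 nM.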

Compound 4, half-maximal cytotoxic concentration: 40000 nM
Estimate against measurement, compound 4: 1.3-fold (0.10 log units) below, within the range that was stated.
By their numbers in this assay, from the lowest: compounds 3, 2, 4 and 1 (each within the scatter of the next).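

Working notes, continued. With the 4-nitrophenyl group in place, the nitro series on this saturated chain carbon bound to an oxygen on an aromatic ring now spans the 2-nitrophenyl, 3-nitrophenyl and 4-nitrophenyl groups, and in this assay the two new nitro comparisons are a 1.3-fold higher number from compound 2 to compound 4 (0.11 log units; within the scatter) and a 1.3-fold lower number from compound 1 to compound 4 (0.11 log units; within the scatter), so none of the three nitrophenyl groups separates from the others. The exchange that alters both the substituent and its ring position at once, a 1.4-fold higher number from compound 3 to compound 4 (0.15 log units; within the scatter), also stays within the scatter, which extends the flat picture from single changes of the substituent or its ring position to a change of both together. No measurement at hand explains why the read-out stays this flat across the four compounds.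

What the compounds shown leave open is whether any aryl substituent other than nitro or methoxy, such as an amine or a carboxylic acid on the same ring, would give a step beyond the scatter in this assay on this core. Also open, going by these compounds, is whether a longer chain between the ether oxygen and the aryl ring would leave the number as unmoved as these four aryl groups have.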